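A few compounds are considered here, and "the series" means these few. Any claim that something is new, unique, unknown or untested is made for them only; others in the source may bear on it.

Measured so far:
compound 1 `CCOC(=O)CN(C)C(=O)c1ccc(C(CC)(CC)c2ccc(OCC(=O)C(C)(C)C)c(C)c2)n1CC`: in an assay on HL-60 cells for agonist activity at vitamin D3 receptor (Homo sapiens), read by microscopy, with a stated time of 96 h (on this read-out higher numbers stand for an effect only at larger amounts of compound and lower numbers for an effect already at smaller amounts), compound 1 gives > 50000 nM, which is a limit of the assay and not a number.
compound 2 `CCn1c(C(=O)NCCN(C)C)ccc1C(CC)(CC)c1ccc(OCC(=O)C(C)(C)C)c(C)c1`: in this assay compound 2 gives 77 nM.
compound 3 `CCOC(=O)CN(C)C(=O)c1ccc(C(CC)(CC)c2ccc(OCC(O)C(C)(C)C)c(C)c2)n1CC`: in this assay compound 3 gives 210 nM.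

Compound 3 stands highest of the two numbers shown in this assay; its nearest neighbour is compound 2, whose number is lower by a gap beyond the scatter. Compound 1 sits at the limit of > 50000 nM in this assay, at which 1 of the 3 values shown sits.

Compound 4 `CCN(CC)CCCNC(=O)c1ccc(C(CC)(CC)c2ccc(OCC(O)C(C)(C)C)c(C)c2)n1CC` differs from compound 3 in one place: (3-(diethylamino)propyl)amino in place of ((ethoxycarbonyl)methyl)(methyl)amino on a carbonyl carbon. Among the compounds with values here, two measured steps bear on it. The closest is an at least 640-fold lower number from compound 1 to compound 2 (2.81 log units; beyond the scatter), the same kind of exchange on a carbonyl carbon, an aminoalkyl amide entering where the ester-bearing amide leaves, on the core that still carries the (tert-butyl)carbonyl. The other is an at least 230-fold lower number from compound 1 to compound 3 (2.37 log units; beyond the scatter), which shows that compound 1's limit can hide a large step. Both steps start from a limit, so their true size is open-ended; still, the expected direction for compound 4 in this assay is a clearly lower number, a step estimated as a 42-fold lower number from compound 3 to compound 4 (1.62 log units; beyond the scatter). Compound 4 is therefore expected near 5 nM, within a range of 0.5 nM to 50 nM.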

Compound 4, half-maximal effective concentration: 66 nM
Estimate against measurement, compound 4: 13-fold (1.12 log units) below, and the stated range ends below it.
By their numbers in this assay, from the lowest: compounds 4 and 2 (each within the scatter of the next); then compound 3. At a limit, above all of these: compound 1.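

Within the data shown here, on the core carrying 1-hydroxy-2,2-dimethylpropyl, exchanging ((ethoxycarbonyl)methyl)(methyl)amino for (3-(diethylamino)propyl)amino on a carbonyl carbon gives, in this assay, a 3.2-fold lower number from compound 3 to compound 4 (0.50 log units; beyond the scatter), the first step at this place with a true number at both ends. The earlier step of this kind starts from compound 1, whose value is a limit of the assay and not a number: the limit of > 50000 nM in this assay, at which 1 of the 4 values shown sits. That earlier step, an at least 640-fold lower number from compound 1 to compound 2 (2.81 log units; beyond the scatter), also brings in a different group, (2-(dimethylamino)ethyl)amino, on the core with (tert-butyl)carbonyl, so it cannot be taken as the size of the exchange on the core of compound 3, where the measured change stays modest though beyond the scatter.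

As far as these compounds go, it remains open how much of the step belongs to the diethylamino end and how much to the chain or to the loss of the ethyl ester, and a carboxylic acid in place of that ester, a primary amine at the chain end or a longer chain would separate these. Also open, from the compounds shown here alone, is how (3-(diethylamino)propyl)amino reads on the core with (tert-butyl)carbonyl, the pairing that would show whether the two changes add.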